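The source may report more compounds than this note shows. Statements on the series, on what has been measured and on what is new or still open speak of the compounds shown alone.

Compound 1 `COC(=O)[C@@]1(C)CCC=C2[C@@H]1CC[C@@H](C)[C@]2(C)Cc1c[nH]c2ccc(C)cc12` gives 20000 nM in a functional assay on T47D cells (Homo sapiens) for inhibition, read by sulforhodamine B assay, with a stated time of 48 h; on this read-out higher numbers stand for weaker inhibition of growth and lower numbers for stronger inhibition of growth. Compound 2 `COC(=O)[C@@]1(C)CCC=C2[C@@H]1CC[C@@H](C)[C@]2(C)Cc1c[nH]c2ccc(Br)cc12` carries bromo in place of methyl on an aromatic carbon and gives 16000 nM in this assay; the change made a 1.3-fold lower number from compound 1 to compound 2 (0.10 log units; within the scatter). Compound 3 `COC(=O)[C@@]1(C)CC[C@@H]2C3=C1CC[C@@H](C)[C@]3(C)C[C@@H]1c3cc(C)ccc3N[C@H]21` gives 23000 nM in this assay; the difference between its core and the core of compound 1 is not broken down here, the two holding the same atoms joined differently. Compound 4 `COC(=O)[C@@]1(C)CC[C@@H]2C3=C1CC[C@@H](C)[C@]3(C)C[C@@H]1c3cc(Br)ccc3N[C@H]21` carries bromo in place of methyl on an aromatic carbon. The place differs from the earlier pair in that the ring is part of a fused or bridged system of five rings rather than two rings, so this is the same kind of change, not the same. The step is expected to be a 1.3-fold lower number from compound 3 to compound 4 (0.11 log units; within the scatter), of similar size to the earlier one, resting on a 1.3-fold lower number from compound 1 to compound 2 (0.10 log units; within the scatter). Compound 4 is expected at 18000 nM, estimated between 9000 nM and 36000 nM.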

Compound 4, concentration for 50% growth inhibition: 31000 nM
Beside the measured number, compound 4's estimate is 1.7-fold (0.24 log units) below it; measured number inside the range.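

Bromo in place of methyl on an aromatic carbon gives a 1.3-fold higher number from compound 3 to compound 4 (0.13 log units; within the scatter) in this assay. Set beside the same change on the core of compound 1, this step shows no difference between the two cores: the same change on two cores in this assay, a 1.3-fold lower number (0.10 log units; within the scatter) from compound 1 to compound 2 and a 1.3-fold higher number (0.13 log units; within the scatter) from compound 3 to compound 4, 1.7-fold (0.23 log units) apart, within the scatter of two such steps. The change therefore carries across these two cores without a step that can be told from the scatter on either, but this does not show a shared effect of bromo, and the steps can be given no direction.

Open, from the compounds shown here alone, is whether other groups on this aromatic carbon, such as an amine, a carboxylic acid or a longer chain, would move the number beyond the scatter on either core. Also open, going by these compounds, is whether any such step would carry from one core to the other.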